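Dimethylamino to diethylamino at the end of a chain

The source may report more compounds than this note shows. Statements on the series, on what has been measured and on what is new or still open speak of the compounds shown alone.

In a functional assay on A549 cells (Homo sapiens) for antiproliferative activity, read by MTT assay, with a stated time of 48 h (a higher number here means a weaker inhibitor, a lower number a stronger inhibitor), compound 1 (`Cn1c(N)c(-c2nc3ccccc3[nH]2)c2nc(C#N)c(C#N)nc21`) gives only a limit (> 50000 nM). Compound 3 (`CN(C)CCCCn1c(-c2c(N)n(C)c3nc(C#N)c(C#N)nc23)nc2ccccc21`) gives 11200 nM and compound 2 (`N#Cc1nc2c(-c3nc4ccccc4o3)c(N)n(CCCN3CCCCC3)c2nc1C#N`) gives 8670 nM in the same assay, and these two values lie within the scatter of each other. Compound 4 (`CCN(CC)CCCCn1c(-c2c(N)n(C)c3nc(C#N)c(C#N)nc23)nc2ccccc21`) differs from compound 3 in one place (diethylamino in place of dimethylamino on a saturated chain carbon, four bonds along the chain from an aromatic nitrogen): diethylamino in place of dimethylamino on a saturated chain carbon, four bonds along the chain from an aromatic nitrogen. The measured step of an at least 4.4-fold lower number from compound 1 to compound 3 (0.64 log units; beyond the scatter) puts 4-(dimethylamino)butyl in place of hydrogen on an aromatic nitrogen. It concerns the whole chain, not its end group, so no step beyond the scatter is expected in this assay for compound 4. The expected change is a 1.2-fold lower number from compound 3 to compound 4 (0.07 log units; within the scatter) as estimated here. Compound 4 is estimated at 9500 nM (expected range 4000 nM to 22000 nM).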

Compound 4, half-maximal inhibitory concentration: 13100 nM
Beside the measured number, compound 4's estimate is 1.4-fold (0.14 log units) below it; the range from low to high includes it.
By their numbers in this assay, from the lowest: compounds 2, 3 and 4 (each within the scatter of the next). At a limit, above all of these: compound 1.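

In this assay, the end of the chain at this position accepted a larger amine without a step beyond the scatter: a 1.2-fold higher number from compound 3 to compound 4 (0.07 log units; within the scatter). The step from hydrogen on the aromatic nitrogen also held with the new end group: an at least 3.8-fold lower number from compound 1 to compound 4 (0.58 log units; beyond the scatter). That step is only a bound, since compound 1 stands at a limit: the limit of > 50000 nM in this assay, at which 1 of the 4 values shown sits.

The compounds shown leave open whether a morpholine or a primary amine at the chain end, or a carboxylic acid there instead of an amine, would move the number beyond the scatter. On these data alone, a longer chain also remains open.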